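Trifluoromethyl in Place of Chloro on Compound 1

The source may report more compounds than this note shows. Statements on the series, on what has been measured and on what is new or still open speak of the compounds shown alone.

Measured so far:
compound 1, `O=c1c(-c2nn[nH]n2)c[nH]c2c(Cl)cccc12`, in a functional assay on the whole organism (strain Sprague-Dawley) for inhibition, with Rattus norvegicus as the target (on this read-out higher numbers stand for an effect only at larger amounts of compound and lower numbers for an effect already at smaller amounts), gives 0.078 mg/kg.
compound 2, `O=c1c(-c2nn[nH]n2)c[nH]c2c(Cl)ccc(Cl)c12`, in this assay reaches only an assay limit of > 0.156 mg/kg.
compound 3, `COc1ccc2cc(C(=O)O)cnc2c1`, in this assay reaches only an assay limit of > 25 mg/kg.

Within the data shown here, compound 1 therefore stands as the only measured number on this read-out; the two other results are limits, namely the limit of > 0.156 mg/kg in this assay, at which 1 of the 3 values shown sits, and (the limit of > 25 mg/kg in this assay, at which 1 of the 3 values shown sits). Among the measured compounds shown here, the one step between neighbours, an at least 2.0-fold higher number from compound 1 to compound 2 (0.30 log units; that floor lies within the scatter), concerns a second chloro entering and its floor lies within the scatter, so it says little about the size of any change at the first chloro.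

The unmeasured compound 4, `O=c1c(-c2nn[nH]n2)c[nH]c2c(C(F)(F)F)cccc12`, differs from compound 1 by trifluoromethyl in place of chloro on an aromatic carbon. For the measured compounds named here, no measured pair swaps chloro for trifluoromethyl, and compound 3 has a different core, so its limit gives no guide either. With nothing pointing to a shift in either direction, the step from compound 1 to compound 4 is expected to stay within the scatter, estimated as a 1.3-fold higher number from compound 1 to compound 4 (0.11 log units; within the scatter). On that basis compound 4 is expected to give about 0.1 mg/kg, with a plausible range from 0.03 mg/kg to 0.4 mg/kg.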

Compound 4, minimum effective dose: 0.156 mg/kg
Estimate against measurement, compound 4: 1.6-fold (0.19 log units) below; the range from low to high includes it.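

In this assay the change of chloro to trifluoromethyl on an aromatic carbon gives a 2.0-fold higher number from compound 1 to compound 4 (0.30 log units; within the scatter), so at this position a group with 4 heavy atoms can stand in place of one with 1 heavy atom and the two values still lie within the scatter of each other. Among these compounds, the earlier compounds could not show this, as their only step concerned a second chloro entering and ended on a limit, whereas here both ends of the step are measured numbers and the change falls on the first chloro itself. Nothing among the results shown bears on why the two groups read alike.

Still open, on these data alone, is whether this position tolerates other groups in the same way, for instance a methoxy, a nitrile or an amine on the same aromatic carbon, or plain hydrogen with no group there at all. Also open, as far as these compounds go, is how trifluoromethyl at this place would read with a second chloro on the core, as in compound 2.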